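The source may report more compounds than this note shows. Statements on the series, on what has been measured and on what is new or still open speak of the compounds shown alone.

Measured so far in a functional assay on THP-1 cells (Homo sapiens) for cytotoxicity, read by MTT assay, with a stated time of 24 h; a higher number here means a weaker inhibitor, a lower number a stronger inhibitor (one value per compound):
- Compound 1 `CN1C/C(=C\c2cccc([N+](=O)[O-])c2)C(=O)/C(=C/c2ccccc2F)C1` gives 1010 nM
- Compound 2 `COc1cc(/C=C2\CN(C)C/C(=C\c3ccc(Cl)cc3)C2=O)cc(OC)c1` gives 5860 nM
- Compound 3 `COc1cc(/C=C2\CN(C)C/C(=C\c3ccc(Cl)c(Cl)c3)C2=O)cc(OC)c1OC` gives 5330 nM

Compound 1 has the lowest number of the three, and its gaps to compound 2 and compound 3 both lie beyond the usual scatter. Compound 4 `CN1C/C(=C\c2cccc([N+](=O)[O-])c2)C(=O)/C(=C/c2ccc(Cl)c(Cl)c2)C1` is not yet measured. Its change from compound 1 is 3,4-dichlorophenyl in place of 2-fluorophenyl on a double-bonded chain carbon bound to a double-bonded ring carbon and consists of 3,4-dichlorophenyl in place of 2-fluorophenyl on a double-bonded chain carbon bound to a double-bonded ring carbon. Compound 3 also carries 3,4-dichlorophenyl and gives a higher number (5330 nM), but it differs from compound 1 elsewhere too, so it is only a weak guide. The expected step of a 1.8-fold higher number from compound 1 to compound 4 (0.25 log units; within the scatter) in this assay is moderate, towards a higher number. For compound 4 the estimated value is 1800 nM (range 600 nM to 5000 nM).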

Compound 4, half-maximal inhibitory concentration: 5020 nM
Estimate against measurement, compound 4: 2.8-fold (0.45 log units) below, outside the stated range (above it).
By their numbers in this assay, from the lowest: compound 1; then compounds 4, 3 and 2 (each within the scatter of the next).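

Going by these compounds alone, with the rest of compound 1 held constant, 3,4-dichlorophenyl in place of 2-fluorophenyl on a double-bonded chain carbon bound to a double-bonded ring carbon gives a 5.0-fold higher number from compound 1 to compound 4 (0.70 log units; beyond the scatter) in this assay as the first single-place comparison. This position alone can therefore shift the number beyond the scatter, in the direction of a weaker inhibitor.

On these data alone, whether an unsubstituted phenyl or a pyridine ring here would sit nearer compound 1 or compound 4 remains open, as does whether the step persists with another group replacing the nitrophenyl. The data shown offer no measured basis for explaining this step.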